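A few compounds are considered here, and "the series" means these few. Any claim that something is new, unique, unknown or untested is made for them only; others in the source may bear on it.

Measured in a functional assay on A549 cells (Homo sapiens) for cytotoxicity, read by MTT assay, with a stated time of 72 h; a lower number here means a stronger inhibitor, a higher number a weaker inhibitor:
- Compound 1 `O=C(N/N=C/c1cccc(Cl)c1Cl)Nc1cc2c(Nc3ccc(F)c(Cl)c3)ncnc2cc1O[C@H]1CCOC1`: 25000 nM
- Compound 2 `COc1ccc(/C=N/NC(=O)Nc2cc3c(Nc4ccc(F)c(Cl)c4)ncnc3cc2O[C@H]2CCOC2)cc1`: 33100 nM
- Compound 3 `CCN(CC)c1ccc(/C=N/NC(=O)Nc2cc3c(Nc4ccc(F)c(Cl)c4)ncnc3cc2O[C@H]2CCOC2)c(O)c1`: 15700 nM

Compound 2 stands at the upper end of this small set. The step to its nearest neighbour is a 1.3-fold higher number from compound 1 to compound 2 (0.12 log units; within the scatter), and the step to its furthest is a 2.1-fold lower number from compound 2 to compound 3 (0.32 log units; beyond the scatter).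

Compound 4 `COc1ccc(/C=N/NC(=O)Nc2cc3c(Nc4ccc(F)c(Cl)c4)ncnc3cc2OC)cc1` departs from compound 2 in a single place: methyl in place of oxolan-3-yl on an oxygen on an aromatic ring. In words, it has methyl in place of oxolan-3-yl on an oxygen on an aromatic ring. Within the data shown here, no measured step touches this group. All three change only the group on a carbon with a double bond to nitrogen, so they bear on it only indirectly, by showing how little the numbers have moved so far. Besides the two steps above, there is a 1.6-fold lower number from compound 1 to compound 3 (0.20 log units; within the scatter). They give no direction for the new change, and no step beyond the scatter is expected in this assay. The estimate amounts to an expected 1.1-fold lower number from compound 2 to compound 4 (0.04 log units; within the scatter). For compound 4 the expected value is 30000 nM, with an estimated range of 14000 nM to 65000 nM.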

Compound 4, half-maximal inhibitory concentration: 28100 nM
For compound 4 the middle estimate is 1.1-fold (0.03 log units) above the measured one, within the range that was stated.
By their numbers in this assay, from the lowest: compounds 3, 1, 4 and 2 (each within the scatter of the next, the first and the last beyond it).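

In this assay, the change from oxolan-3-yl to methyl on an oxygen on an aromatic ring gives a 1.2-fold lower number from compound 2 to compound 4 (0.07 log units; within the scatter). Among these compounds, this is the first reading at this position, as the earlier steps all changed the group on a carbon with a double bond to nitrogen, and it shows that, with 4-methoxyphenyl held fixed, neither the ring nor the defined stereocentre of oxolan-3-yl is needed to keep the number at the level of compound 2. No measurement shown here accounts for this result.

As far as these compounds go, whether the same swap would leave the number within the scatter alongside 4-(diethylamino)-2-hydroxyphenyl or 2,3-dichlorophenyl remains open. From the compounds shown here alone, it is also open whether a longer chain on this oxygen, ending in a tertiary amine or a carboxylic acid, would move the number beyond the scatter.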